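This account rests on a few compounds, and the source may have more. Where it says the series, first, only, none or still open, it means among the compounds named here.

In a functional assay on MCF7 cells (Homo sapiens) for antiproliferative activity, read by MTT assay, with a stated time of 48 h (a higher number here means a weaker inhibitor, a lower number a stronger inhibitor), compound 1 (`COc1ccc2nc(NC(c3cn(-c4ccccc4)nc3-c3ccc(Cl)cc3)c3c(O)ccc4ccccc34)sc2c1`) gives 23700 nM and compound 2 (`O=[N+]([O-])c1cccc(-c2nn(-c3ccccc3)cc2C(Nc2nc3ccc(Cl)cc3s2)c2c(O)ccc3ccccc23)c1`) gives 19700 nM as its value, so these two stand within the scatter of each other. Compound 3 (`Oc1ccc2ccccc2c1C(Nc1nc2ccc(Cl)cc2s1)c1cn(-c2ccccc2)nc1-c1ccc(Cl)cc1`) differs from compound 2 by 4-chlorophenyl in place of 3-nitrophenyl on an aromatic carbon. Going by the values given here, no step between measured compounds speaks to this change, so no shift beyond the scatter is expected in this assay for it. The expected move is a 1.1-fold higher number from compound 2 to compound 3 (0.03 log units; within the scatter) and it stays within the scatter. Compound 3 is estimated at 21000 nM with a range of 9000 nM to 50000 nM expected.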

Compound 3, half-maximal inhibitory concentration: 27500 nM
Estimate against measurement, compound 3: 1.3-fold (0.12 log units) below, within the range that was stated.
By their numbers in this assay, from the lowest: compounds 2, 1 and 3 (each within the scatter of the next).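

In this assay, 4-chlorophenyl in place of 3-nitrophenyl on this aromatic carbon of the five-membered ring gives a 1.4-fold higher number from compound 2 to compound 3 (0.14 log units; within the scatter), so this position tolerates the swap of these two aryl groups without a change beyond the scatter. The second single change, chloro in place of methoxy on an aromatic carbon, gives a 1.2-fold higher number from compound 1 to compound 3 (0.06 log units; within the scatter), also within the scatter. No measured evidence accompanies these steps. As far as these compounds go, whether an amine or a carboxylic acid on either aromatic carbon would move the number beyond the scatter remains open. So does whether replacing the hydroxyl of the shared core with a methoxy would.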